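This account rests on a few compounds, and the source may have more. Where it says the series, first, only, none or still open, it means among the compounds named here.

Of the compounds shown here, three sharing one core have been measured in a functional assay on UACC-257 cells (Homo sapiens) for inhibition, read by sulforhodamine B assay, with a stated time of 48 h; on this read-out higher numbers stand for weaker inhibition of growth and lower numbers for stronger inhibition of growth. Compound 1 `O=C(Nc1cccc(-n2cc(-c3ccncc3)c(-c3ccc(Cl)c(O)c3)n2)c1)Nc1cccc(C(F)(F)F)c1` gives 19100 nM. Compound 2 `COc1cc(-c2nn(-c3cccc(NC(=O)Nc4cc(C(F)(F)F)cc(C(F)(F)F)c4)c3)cc2-c2ccncc2)ccc1Cl` gives 2350 nM, the second highest of the three numbers. Its nearest neighbour is compound 3 `COc1cc(-c2nn(-c3cccc(NC(=O)Nc4cccc(C(F)(F)F)c4)c3)cc2-c2ccncc2)ccc1Cl`, which gives 2310 nM, a value within the scatter of compound 2; the furthest is compound 1, whose number is beyond the scatter higher.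

The step to the unmeasured compound 4 `O=C(Nc1cccc(-n2cc(-c3ccncc3)c(-c3ccc(Cl)c(O)c3)n2)c1)Nc1cc(C(F)(F)F)cc(C(F)(F)F)c1` is hydrogen in place of methyl on an oxygen on an aromatic ring. Going by the values given here, two measured steps bear on it. The step from compound 1 to compound 3 is the same change run the other way, and it gave an 8.3-fold lower number from compound 1 to compound 3 (0.92 log units; beyond the scatter). The step from compound 2 to compound 3 shows that the second trifluoromethyl on the terminal ring makes no difference here, giving a 1.0-fold lower number from compound 2 to compound 3 (0.01 log units; within the scatter), so the pairing of the hydroxy group with the bis-trifluoromethyl ring in compound 4 is expected to behave as it does in compound 1.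

Compound 4 is therefore expected to give a higher number than compound 2, with the expected step being a 7.7-fold higher number from compound 2 to compound 4 (0.88 log units; beyond the scatter), because the reverse change gave an 8.3-fold lower number from compound 1 to compound 3 (0.92 log units; beyond the scatter). The estimate for compound 4 is 18000 nM, in the range 6000 nM to 50000 nM.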

Compound 4, concentration for total growth inhibition: 2550 nM
For compound 4 the middle estimate is 7.1-fold (0.85 log units) above the measured one, outside the stated range (below it).
By their numbers in this assay, from the lowest: compounds 3, 2 and 4 (each within the scatter of the next); then compound 1.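

In this assay the change from methoxy to hydroxy on an oxygen on an aromatic ring proves not to be a fixed penalty, since with two trifluoromethyl groups on the terminal ring it gives a 1.1-fold higher number from compound 2 to compound 4 (0.04 log units; within the scatter) and the large shift seen with one trifluoromethyl does not carry over: the same change on two cores in this assay, an 8.3-fold lower number (0.92 log units; beyond the scatter) from compound 1 to compound 3 and a 1.1-fold lower number (0.04 log units; within the scatter) from compound 4 to compound 2, 7.6-fold (0.88 log units) apart, beyond the scatter of two such steps.
The second trifluoromethyl, silent on the methoxy compounds, counts on the hydroxy compounds, where it gives a 7.5-fold lower number from compound 1 to compound 4 (0.87 log units; beyond the scatter) and so depends on the group at that oxygen: the same change on two cores in this assay, a 1.0-fold lower number (0.01 log units; within the scatter) from compound 2 to compound 3 and a 7.5-fold higher number (0.87 log units; beyond the scatter) from compound 4 to compound 1, 7.6-fold (0.88 log units) apart, beyond the scatter of two such steps.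
The two changes therefore do not add up, and among these compounds the hydroxy group goes with a higher number only where the terminal ring carries a single trifluoromethyl.

As far as these compounds go, what lies behind this dependence stays open, and four compounds cannot show whether it is general. Nor do they tell how an ethoxy group or an amine at that place would behave, or whether a chlorine or a nitrile in place of the second trifluoromethyl would restore the number in the same way.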